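The source may report more compounds than this note shows. Statements on the series, on what has been measured and on what is new or still open speak of the compounds shown alone.

Measured so far in a functional assay on NCI-H226 cells (Homo sapiens) for inhibition, read by MTT assay, with a stated time of 72 h; a higher number here means a weaker inhibitor of growth, a lower number a stronger inhibitor of growth:
- compound 1 `COC(=O)c1nc(C)n(-c2ccc(C(F)(F)F)cc2)n1`: 16600 nM
- compound 2 `COC(=O)c1nc(C)n(-c2ccc(OC)cc2)n1`: > 100000 nM, a limit of the assay

Among the measured compounds shown here, compound 1 holds the only number measured here. Compound 2 `COC(=O)c1nc(C)n(-c2ccc(OC)cc2)n1` gives only > 100000 nM, which is a limit of the assay (the limit of > 100000 nM in this assay, at which 1 of the 2 values shown sits). The step of an at least 6.0-fold higher number from compound 1 to compound 2 (0.77 log units; beyond the scatter) concerns a different place. Compound 3 `COC(=O)c1nc(-c2ccsc2)n(-c2ccc(C(F)(F)F)cc2)n1` differs from compound 1 by thiophen-3-yl in place of methyl on an aromatic carbon. For the measured compounds named here, no measured step touches this position, so no direction can be drawn from the data; the expected step of a 1.4-fold lower number from compound 1 to compound 3 (0.14 log units; within the scatter) is small. Compound 3 is therefore estimated at 12000 nM, between 3000 nM and 60000 nM.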

Compound 3, concentration for 50% growth inhibition: 5740 nM
Estimate against measurement, compound 3: 2.1-fold (0.32 log units) above, and the stated range covers the measured number.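

In this assay, thiophen-3-yl in place of methyl gives a 2.9-fold lower number from compound 1 to compound 3 (0.46 log units; beyond the scatter). Among the compounds shown here, this is the first measured step at this position, on the aromatic carbon between two ring nitrogen atoms, and it shows that the methyl is not needed for growth inhibition and that a five-membered aromatic ring can stand there with a lower number. Nothing measured here accounts for the drop. The compounds shown leave open whether a phenyl ring, an amine or a longer alkyl chain at this position would give a similar step. Also open, as far as these compounds go, is whether the step would hold with methoxy in place of trifluoromethyl.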